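Aryl urea series: chloro added beside the trifluoromethyl

A few compounds are considered here, and "the series" means these few. Any claim that something is new, unique, unknown or untested is made for them only; others in the source may bear on it.

Compound 1 `O=C(Nc1cccc(-n2cc(-c3ccncc3)c(-c3ccc(Cl)c(O)c3)n2)c1)Nc1cccc(C(F)(F)F)c1` is the reference point of the series. Among the measured compounds shown here, in a functional assay on NCI-H522 cells (Homo sapiens) for inhibition, read by sulforhodamine B assay, with a stated time of 48 h (on this read-out higher numbers stand for weaker inhibition of growth and lower numbers for stronger inhibition of growth), compound 1 gives 14500 nM, the highest of the three numbers measured so far. Compound 2 `COc1cc(-c2nn(-c3cccc(NC(=O)Nc4cccc(C(F)(F)F)c4)c3)cc2-c2ccncc2)ccc1Cl` carries a methyl in place of hydrogen on an oxygen on an aromatic ring; in this assay compound 2 gives 2430 nM, and the step of a 6.0-fold lower number from compound 1 to compound 2 (0.78 log units; beyond the scatter) lies beyond the scatter. Compound 3 `O=C(Nc1cccc(-n2cc(-c3ccncc3)c(-c3ccc(Cl)c(O)c3)n2)c1)Nc1cc(C(F)(F)F)cc(C(F)(F)F)c1` carries a trifluoromethyl in place of hydrogen on an aromatic carbon; in this assay compound 3 gives 2510 nM, and the step of a 5.8-fold lower number from compound 1 to compound 3 (0.76 log units; beyond the scatter) is of the same modest size. Compound 4 `O=C(Nc1cccc(-n2cc(-c3ccncc3)c(-c3ccc(Cl)c(O)c3)n2)c1)Nc1ccc(Cl)c(C(F)(F)F)c1` has not been measured. It differs from compound 1 by chloro in place of hydrogen on an aromatic carbon, the chloro entering ortho to a trifluoromethyl group. Of the two measured steps, a 5.8-fold lower number from compound 1 to compound 3 (0.76 log units; beyond the scatter) bears most directly on this change: it too adds a group on the 3-(trifluoromethyl)phenyl ring. The step to compound 2 alters a different part of the molecule and is taken only as a sign that small additions in this series have so far lowered the number. For the measured compounds named here, a step in the same direction, somewhat smaller than the one to compound 3, is therefore expected, namely a 3.2-fold lower number from compound 1 to compound 4 (0.51 log units; beyond the scatter). On that basis compound 4 is estimated at 4500 nM in this assay, with a range from 1500 nM to 14000 nM.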

Compound 4, concentration for total growth inhibition: 2500 nM
The estimate for compound 4 lay 1.8-fold (0.26 log units) above the measured number; the measured number falls inside the stated range.
By their numbers in this assay, from the lowest: compounds 2, 4 and 3 (each within the scatter of the next); then compound 1.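

In this assay, chloro in place of hydrogen on an aromatic carbon, ortho to a trifluoromethyl group and para to a large group, gives a 5.8-fold lower number from compound 1 to compound 4 (0.76 log units; beyond the scatter), so this position on the 3-(trifluoromethyl)phenyl ring takes a chlorine atom with a lower number rather than a higher one. Set against a 5.8-fold lower number from compound 1 to compound 3 (0.76 log units; beyond the scatter), this shows two different additions to the same ring, chloro and trifluoromethyl, lowering the number by steps of matching size, and neither of the two compounds carrying such an addition goes against that pattern. The data include no independent measurement that could explain this step, so its origin stays unassigned.

The compounds shown do not tell whether the step is specific to chloro or would also appear with a different group at this position, such as a methyl, a methoxy, an amine or a carboxylic acid. They also leave open whether the chloro of compound 4 and the methyl on oxygen of compound 2, placed in one molecule, would lower the number further than either change alone.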